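This account rests on a few compounds, and the source may have more. Where it says the series, first, only, none or still open, it means among the compounds named here.

Compound 1 (`COc1ccc(-c2oc3c(CC=C(C)C)c(OC(C(=O)O)C(=O)O)cc(O)c3c(=O)c2OC(C(=O)O)C(=O)O)cc1`) and compound 2 (`CCOC(=O)C(C)Oc1cc(O)c2c(=O)c(O)c(-c3ccc(OC)cc3)oc2c1CC=C(C)C`) are the starting points here. In an ADME assay on Vero cells (Chlorocebus sabaeus) for cytotoxicity, read by MTT assay (a lower number here means a stronger inhibitor, a higher number a weaker inhibitor), compound 1 carries the entry "not determined" (no result reported) and so offers no number, while compound 2 gives 1400 nM as the only figure available, which leaves nothing to rank it against. Compound 3 (`COc1ccc(-c2oc3c(CC=C(C)C)c(OC(C)C(=O)O)cc(O)c3c(=O)c2O)cc1`) differs from compound 2 in one place: the change hydrogen in place of ethyl on an oxygen next to a carbonyl group puts hydrogen in place of ethyl on an oxygen next to a carbonyl group, turning ethoxycarbonyl to carboxy. For the measured compounds named here, no measured pair shows what such a change does, so the size of the step is a judgement with wide uncertainty. A move toward a higher number, meaning a weaker inhibitor, is expected, probably beyond the usual scatter. The expected step of a 5.7-fold higher number from compound 2 to compound 3 (0.76 log units; beyond the scatter) is only an estimate. Compound 3 is estimated at 8000 nM with 2000 nM to 40000 nM as the expected range.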

Compound 3, half-maximal inhibitory concentration: 19300 nM
For compound 3 the middle estimate is 2.4-fold (0.38 log units) below the measured one, and the stated range covers the measured number.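

The change from ethoxycarbonyl to carboxy produces a 14-fold higher number from compound 2 to compound 3 (1.14 log units; beyond the scatter) in this assay and counts as a large step. For the compounds shown here, this gives the first measured pair, and it shows that the hydrogen or ethyl on an oxygen next to a carbonyl group strongly affects the read-out, even with the rest of the structure unchanged. No available evidence bears on the reason for this step.

One pair cannot show whether the number rises steadily as the ethyl is shortened or whether hydrogen is a special case, and a methyl in place of ethyl would test this. It also leaves open how a longer chain such as butyl, or an amide made with an amine in place of the ester, would behave at this position.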